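A hydroxy on the amide-type nitrogen

A few compounds are considered here, and "the series" means these few. Any claim that something is new, unique, unknown or untested is made for them only; others in the source may bear on it.

Measured in a physicochemical assay for solubility, read by HPLC, at pH 7.4; on this read-out higher numbers stand for higher solubility and lower numbers for lower solubility:
- compound 1 `CCCCCCCc1[nH]c2ccccc2c(=O)c1C(=O)O` gives 15000 nM
- compound 2 `CCCCCCCc1[nH]c2ccccc2c(=O)c1C(N)=O` gives 5000 nM

Compound 2 holds the lower of the two numbers, and compound 1 stands higher. Compound 3 (`CCCCCCCc1[nH]c2ccccc2c(=O)c1C(=O)NO`) differs from compound 2 by hydroxy in place of hydrogen on an amide-type nitrogen. Among the measured compounds shown here, the only measured guide is a 3.0-fold lower number from compound 1 to compound 2 (0.48 log units; beyond the scatter) (amino in place of hydroxy on a carbonyl carbon), a modest step beyond the scatter, though it is a different change. A rise of similarly modest size is therefore expected in this assay (a 1.6-fold higher number from compound 2 to compound 3 (0.20 log units; within the scatter)). Compound 3 is estimated at 8000 nM (range 3000 nM to 20000 nM).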

Compound 3, solubility: > 200000 nM
Compound 3: no number, only a limit; the forecaster's own chance of this, stated with the estimate: 5%; at least 25-fold (1.39 log units) between middle value and limit.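

The value of compound 3 in this assay is a limit of the assay and not a number: the limit of > 200000 nM in this assay, at which 1 of the 3 values shown sits. Hydroxy in place of hydrogen on the amide-type nitrogen gives an at least 40-fold higher number from compound 2 to compound 3 (1.60 log units; beyond the scatter), and hydroxyamino in place of hydroxy on the carbonyl carbon gives an at least 13-fold higher number from compound 1 to compound 3 (1.12 log units; beyond the scatter). This position therefore allows large steps, not only the modest one seen earlier, and compound 3 stands highest of the three. The compounds shown leave open whether a methoxy group on that nitrogen would give a step of similar size, and whether the step would persist with a shorter chain on the shared core.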